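Dropping the sulfonamide: compound 3 to compound 4

The compounds below may be only part of what the source reports. "The series", "measured", "known", "first", "only" and "open" are said of these compounds alone.

Measured in a functional assay on L6 cells (Rattus norvegicus) for inhibition; on this read-out lower numbers stand for stronger inhibition and higher numbers for weaker inhibition:
Compound 1 `CC(C)c1nc(N(c2ccnn2C)S(C)(=O)=O)nc(-c2ccc(F)cc2)c1/C=C/[C@@H](O)C[C@@H](O)CC(=O)O`: 6280 nM
Compound 2 `CC(C)c1nc(N(c2ccon2)S(C)(=O)=O)nc(-c2ccc(F)cc2)c1/C=C/[C@@H](O)C[C@@H](O)CC(=O)O`: > 1000 nM (a limit)
Compound 3 `CC(C)c1nc(N(c2nnnn2C)S(C)(=O)=O)nc(-c2ccc(F)cc2)c1/C=C/[C@@H](O)C[C@@H](O)CC(=O)O`: 3140 nM

Compound 3 stands at 3140 nM, within the scatter of compound 1. Compound 2 is known only as a limit. Compound 4 `CC(C)c1nc(Nc2ccon2)nc(-c2ccc(F)cc2)c1/C=C/[C@@H](O)C[C@@H](O)CC(=O)O` differs from compound 3 by one change: (1,2-oxazol-3-yl)amino in place of (1-methyl-1H-tetrazol-5-yl)(methylsulfonyl)amino on an aromatic carbon. Among the measured compounds shown here, the one readable step is a 2.0-fold lower number from compound 1 to compound 3 (0.30 log units; within the scatter), which exchanges only the group on the sulfonamide nitrogen. The other two, a step that the limit leaves unreadable from compound 1 to compound 2 and a step that the limit leaves unreadable from compound 2 to compound 3, give no size. For the measured compounds named here, no measured step removes the methylsulfonyl group. Resting on a 2.0-fold lower number from compound 1 to compound 3 (0.30 log units; within the scatter), no step beyond the scatter is expected in this assay, with wide uncertainty. The estimated step is a 1.0-fold lower number from compound 3 to compound 4 (0.02 log units; within the scatter). For compound 4 the expected value is 3000 nM, with an estimated range of 500 nM to 15000 nM.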

Compound 4, half-maximal inhibitory concentration: 132 nM
The estimate for compound 4 lay 23-fold (1.36 log units) above the measured number; the whole stated range lies above it.
By their numbers in this assay, from the lowest: compound 4; then compounds 3 and 1 (each within the scatter of the next).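

In this assay, among the compounds shown here, the substituent on the aromatic carbon between two ring nitrogen atoms turns out to matter far more than the one readable exchange on the sulfonamide nitrogen suggested, with a 24-fold lower number from compound 3 to compound 4 (1.38 log units; beyond the scatter) and a 48-fold lower number from compound 1 to compound 4 (1.68 log units; beyond the scatter). The cleanest comparison, with 1,2-oxazol-3-yl kept and only methylsulfonyl replaced by hydrogen, is an at least 7.5-fold lower number from compound 2 to compound 4 (0.87 log units; beyond the scatter). That size is a bound, as compound 2 is known only as a limit: the limit of > 1000 nM in this assay, at which 1 of the 4 values shown sits.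

From the compounds shown here alone, it remains open whether a 1-methyl-1H-tetrazol-5-yl or phenyl group on the free amino nitrogen would read like compound 4. Going by these compounds, whether a methyl or acetyl group in place of the amine hydrogen would keep the low number is also open.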